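From Amide to Ester on a Shared Core

The source may report more compounds than this note shows. Statements on the series, on what has been measured and on what is new or still open speak of the compounds shown alone.

Compound 1 `Nc1sc(-c2ccc(Cl)cc2)c(-c2ccc(Cl)cc2)c1C(=O)Nc1ccccc1` and compound 2 `Nc1sc(-c2ccc(Cl)cc2)c(-c2ccc(Cl)cc2)c1C(=O)N1CCCC1` share one core and differ only at the carbonyl carbon. In a functional assay on SW-620 cells (Homo sapiens) for cytotoxicity, read by sulforhodamine B assay, with a stated time of 72 h (on this read-out lower numbers stand for stronger inhibition and higher numbers for weaker inhibition), compound 1 gives 39700 nM, while compound 2 gives 3870 nM; the step is a 10-fold lower number from compound 1 to compound 2 (1.01 log units; beyond the scatter). Within the data shown here, compound 2 therefore holds the lower of the two numbers so far. Compound 3 `COC(=O)c1c(N)sc(-c2ccc(Cl)cc2)c1-c1ccc(Cl)cc1` carries methoxy in place of pyrrolidin-1-yl on a carbonyl carbon. Among the measured compounds shown here, the single measured step bears on this only loosely, since it exchanged one group on the carbonyl carbon for another of a different kind, so the direction is uncertain. A small step is expected, a 1.6-fold higher number from compound 2 to compound 3 (0.19 log units; within the scatter). Compound 3 is estimated at 6000 nM, within 1500 nM to 25000 nM.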

Compound 3, half-maximal inhibitory concentration: 3230 nM
Estimate against measurement, compound 3: 1.9-fold (0.27 log units) above; the measured number falls inside the stated range.
By their numbers in this assay, from the lowest: compounds 3 and 2 (each within the scatter of the next); then compound 1.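

In this assay the change to methoxy gives a 1.2-fold lower number from compound 2 to compound 3 (0.08 log units; within the scatter) and so the pyrrolidin-1-yl ring and its nitrogen are not required on this carbonyl carbon for a number of this size. Only the anilino group of compound 1 stands apart so far, with a 12-fold lower number from compound 1 to compound 3 (1.09 log units; beyond the scatter). No measurement shown explains either step.

From the compounds shown here alone, whether a carboxylic acid, a longer chain such as ethoxy or an unsubstituted amide on this carbonyl carbon would fit with compound 2 and compound 3 remains open. So does whether the phenyl ring or the amide hydrogen of the anilino group accounts for the higher number of compound 1.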